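Inverting one ring stereocentre of compound 1

A few compounds are considered here, and "the series" means these few. Any claim that something is new, unique, unknown or untested is made for them only; others in the source may bear on it.

In a functional assay on SK-MEL-28 cells (Homo sapiens) for inhibition, read by MTT assay, with a stated time of 72 h (on this read-out lower numbers stand for stronger inhibition and higher numbers for weaker inhibition), compound 1 (`C/C1=C\CC[C@@]2(C)O[C@@H]2[C@H]2OC(=O)[C@@H](CN3CCCC3)[C@@H]2C[C@H]1O`) gives 19000 nM and compound 3 (`C/C1=C\CC[C@@]2(C)O[C@@H]2[C@H]2OC(=O)[C@@H](CN(C)CCN(C)C)[C@@H]2C[C@H]1O`) gives 19000 nM, together the lowest of the three numbers, while compound 2 (`C/C1=C\CC[C@@]2(C)O[C@@H]2[C@H]2OC(=O)[C@@H](CN3CCN(C)CC3)[C@@H]2C[C@H]1O`) gives 57000 nM. Compound 4 (`C/C1=C\CC[C@@]2(C)O[C@@H]2[C@H]2OC(=O)[C@@H](CN3CCCC3)[C@@H]2C[C@@H]1O`) departs from compound 1 thus: the two compounds have the same atoms and bonds and differ only in configuration as drawn: 1 of 7 stereo elements differ; a stereocentre at a saturated ring carbon is drawn R in compound 1 and S in compound 4. A stereocentre at a saturated ring carbon is drawn R in compound 1 and S in compound 4. The measured steps only exchange the amine: a 3.0-fold higher number from compound 1 to compound 2 (0.48 log units; beyond the scatter) and no change at the digits printed from compound 1 to compound 3 (within the scatter). None tests a stereocentre, so they give no direction and only a rough scale. No step beyond the scatter is therefore expected in this assay, though the uncertainty is wide. The expected step is a 1.3-fold higher number from compound 1 to compound 4 (0.12 log units; within the scatter). Compound 4 is estimated at 25000 nM, with a range of 9000 nM to 70000 nM.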

Compound 4, half-maximal inhibitory concentration: 23000 nM
Compound 4: middle estimate off by 1.1-fold (0.04 log units), on the high side; the range from low to high includes it.
By their numbers in this assay, from the lowest: compounds 1, 3 and 4 (each within the scatter of the next); then compound 2.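

In this assay, inverting this ring stereocentre gives a 1.2-fold higher number from compound 1 to compound 4 (0.08 log units; within the scatter), a reading on configuration that the earlier amine exchanges could not give. The comparison isolates that one centre: the fact that compounds 1 and 4 differ only in the configuration as drawn. With pyrrolidin-1-yl on the chain, this read-out does not separate the R and S drawings at this ring carbon. Open, going by these compounds, is whether the inversion stays equally without effect with 4-methylpiperazin-1-yl or (2-(dimethylamino)ethyl)(methyl)amino on the chain. Also open, on these data alone, is how a morpholin-4-yl group would behave in either configuration.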